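The source may hold more compounds than are shown below. What is called first, only, known or untested is meant among the compounds shown, and "the series" means these compounds.

Working notes on the series. In a functional assay on MDA-MB-435S cells (Homo sapiens) for cytotoxicity, read by MTT assay (on this read-out higher numbers stand for weaker inhibition and lower numbers for stronger inhibition), compound 1 (`CCOC(=O)C(C)Oc1c(-c2ccc(OC)cc2)oc2c(CC=C(C)C)c(O)cc(O)c2c1=O`) gives 4100 nM. Compound 3 (`COc1ccc(-c2oc3c(CC=C(C)C)c(OCCCOC(=O)CCCC(=O)O)cc(O)c3c(=O)c2OCCCOC(=O)CCCC(=O)O)cc1`) gives 8100 nM, which lies within the scatter of the compound 1 number. Compound 2 (`COc1ccc(-c2oc3c(CC=C(C)C)c(OC/C=C/C(=O)O)cc(O)c3c(=O)c2O)cc1`) gives 11300 nM, a higher number than compound 1 by more than the scatter. Compound 1 therefore sits with compound 3 at the low end of the three numbers, and the two cannot be told apart.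

Compound 4 (`CCOC(=O)COc1c(-c2ccc(OC)cc2)oc2c(CC=C(C)C)c(O)cc(O)c2c1=O`) departs from compound 1 in one place: hydrogen in place of methyl on a saturated chain carbon bound to a carbonyl carbon and an oxygen on an aromatic ring. This is hydrogen in place of methyl on a saturated chain carbon bound to a carbonyl carbon and an oxygen on an aromatic ring, so 1-(ethoxycarbonyl)ethoxy becomes (ethoxycarbonyl)methoxy.

Among the measured compounds shown here, no two measured compounds differ in one place, so the data give no direct measure of a change of this kind. No step beyond the scatter is expected in this assay, and neither direction is favoured. The expected change is a 1.1-fold higher number from compound 1 to compound 4 (0.04 log units; within the scatter), which stays within the scatter. Compound 4 is estimated at 4500 nM, with an expected range of 2000 nM to 10000 nM.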

Compound 4, half-maximal inhibitory concentration: 30000 nM
Compound 4: middle estimate off by 6.7-fold (0.82 log units), on the low side, outside the stated range (above it).
By their numbers in this assay, from the lowest: compounds 1, 3 and 2 (each within the scatter of the next, the first and the last beyond it); then compound 4.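

In this assay hydrogen in place of methyl on a saturated chain carbon bound to a carbonyl carbon and an oxygen on an aromatic ring gives a 7.3-fold higher number from compound 1 to compound 4 (0.86 log units; beyond the scatter) and so is not a silent change. Among the compounds shown here, this is the first one-place comparison, and it shows that 1-(ethoxycarbonyl)ethoxy and (ethoxycarbonyl)methoxy are not interchangeable on the core of compound 1, with the methyl-bearing compound giving the lower number. Nothing at hand accounts for a step of this size.

As far as these compounds go, whether an ethyl group or a longer chain on the same carbon would continue this trend or reverse it remains open. Also open, from the compounds shown here alone, is whether the methyl matters to the same degree when a carboxylic acid replaces the ethyl ester.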